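The source may hold more compounds than are shown below. What is called first, only, known or untested is meant among the compounds shown, and "the series" means these compounds.

Measured so far:
compound 1 `CC(C)CN(Cc1ccc(N2CCN(S(C)(=O)=O)CC2)cc1)S(=O)(=O)Cc1ccccc1` — <= 1000 nM
compound 2 `CC(C)CN(Cc1ccc(N2CCN(NS(C)(=O)=O)CC2)cc1)S(=O)(=O)Cc1ccccc1` — <= 1000 nM
compound 3 `CC(C)CN(Cc1ccc(N2CCC(O)CC2)cc1)S(=O)(=O)Cc1ccccc1` — 7000 nM

In a physicochemical assay for solubility, in phosphate buffer, measured as kinetic solubility, with a stated time of 24 h, at pH 7.4 (on this read-out lower numbers stand for lower solubility and higher numbers for higher solubility), compound 1 gives <= 1000 nM, which is a limit of the assay, not a number. Compound 2 likewise gives <= 1000 nM, also a limit. Compound 3 gives 7000 nM. Compound 1 thus stands at the limit of <= 1000 nM in this assay, at which 2 of the 3 values shown sit, so its own position is unresolved. Compound 4 `COC1CCN(c2ccc(CN(CC(C)C)S(=O)(=O)Cc3ccccc3)cc2)CC1` differs from compound 1 in one place: 4-methoxypiperidin-1-yl in place of 4-(methylsulfonyl)piperazin-1-yl on an aromatic carbon. The closest measured step, an at least 7.0-fold higher number from compound 1 to compound 3 (0.84 log units; beyond the scatter), removes the same 4-(methylsulfonyl)piperazin-1-yl group, and an at least 7.0-fold higher number from compound 2 to compound 3 (0.84 log units; beyond the scatter) points the same way. A rise beyond the scatter is therefore expected for compound 4, estimated as an at least 3.0-fold higher number from compound 1 to compound 4 (0.47 log units; beyond the scatter), giving 3000 nM in the range 1000 nM to 9000 nM.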

Compound 4, solubility: <= 1000 nM
Compound 4: only a limit was reported; the forecaster's own chance of this, stated with the estimate: 30%; middle value at least 3.0-fold (0.47 log units) from the limit.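

Methyl in place of hydrogen on the oxygen gives an at least 7.0-fold lower number from compound 3 to compound 4 (0.84 log units; beyond the scatter), so losing the 4-(methylsulfonyl)piperazin-1-yl group does not by itself secure a value clear of the limit. In this assay compound 4 gives <= 1000 nM, which is a limit of the assay. The steps linking compound 1 and compound 2 to this compound cannot be read, and the series now clusters at one floor: the limit of <= 1000 nM in this assay, at which 3 of the 4 values shown sit.

On these data alone, how far compound 1, compound 2 and compound 4 lie beneath that limit stays open. Also open, as far as these compounds go, is whether a primary amine or a carboxylic acid in place of the hydroxyl would match compound 3.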